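Moving a Methyl Around the Ring: Expected Cytotoxicity

The source may hold more compounds than are shown below. What is called first, only, known or untested is meant among the compounds shown, and "the series" means these compounds.

Compound 1 `Cc1nc2c(c(-c3cc(F)c4c(c3C)CCCO4)c1[C@H](OC(C)(C)C)C(=O)O)CN(CC1CC1c1ccccc1)CC2` in an ADME assay on MT2 cells (Homo sapiens) for cytotoxicity, read by XTT assay, with a stated time of 4 days (on this read-out higher numbers stand for lower toxicity in this test and lower numbers for higher toxicity in this test), reaches only the limit > 40000 nM, which is a limit of the test and not a number.
Compound 2 `Cc1ccccc1CCCN1CCc2nc(C)c([C@H](OC(C)(C)C)C(=O)O)c(-c3cc(F)c4c(c3C)CCCO4)c2C1` in this assay reaches only the limit > 40000 nM, again a limit and not a number.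

Compound 2 therefore stands at the edge of what this assay can report, and it shares that position with compound 1, as the limit of > 40000 nM in this assay, at which 2 of the 2 values shown sit, shows. For the measured compounds named here, the one step joining the two measured compounds, a step that the two limits leave unreadable from compound 1 to compound 2, cannot be read, since both ends are limits.

Compound 3 `Cc1ccc(CCCN2CCc3nc(C)c([C@H](OC(C)(C)C)C(=O)O)c(-c4cc(F)c5c(c4C)CCCO5)c3C2)cc1` is built from the same atoms as compound 2, joined differently: 4-methylphenyl in place of 2-methylphenyl on a saturated chain carbon, three bonds along the chain from an amine nitrogen in a ring. Going by the values given here, no measured step touches this kind of change, and the only step known at all is unreadable, so there is nothing to point to a rise or a fall. The expectation for the step that the limit leaves unreadable from compound 2 to compound 3 is therefore no movement beyond the scatter. Compound 3 is expected to sit at about 50000 nM, within 20000 nM to 200000 nM, most probably reported again only as a limit.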

Compound 3, half-maximal cytotoxic concentration: > 40000 nM
Compound 3: a limit, no number (the forecaster's own chance of this, stated with the estimate: 85%); the middle value is on the limit's open side.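

Compound 3 gives > 40000 nM as a limit, not a number. The steps to compound 3 from compound 1 and from compound 2 cannot be read, as each joins two limits. Still open, going by these compounds, is whether 4-methylphenyl in place of 2-methylphenyl changes the result at all, and at what concentration any of the three compounds would show toxicity in this assay under these conditions.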